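Aryl change on the amide-type nitrogen, compound 2 to compound 3

A few compounds are considered here, and "the series" means these few. Any claim that something is new, unique, unknown or untested is made for them only; others in the source may bear on it.

Measured so far:
compound 1 `COc1cc(Cl)cc(-c2nn(-c3cccc(NC(=O)Nc4cc(C(F)(F)F)cc(C(F)(F)F)c4)c3)cc2-c2ccncc2)c1`: 99%
compound 2 `COc1cc(Cl)cc(-c2nn(-c3cccc(NC(=O)Nc4ccc(Cl)c(Cl)c4)c3)cc2-c2ccncc2)c1`: 95%

In a functional assay on SF-268 cells (Homo sapiens) for inhibition, read by sulforhodamine B assay, with a stated time of 48 h, tested at 0.1 uM (on this read-out lower numbers stand for a stronger effect and higher numbers for a weaker effect at the one concentration tested), compound 1 gives 99%. In this assay compound 2 gives 95%. Compound 2 has the lowest of the two numbers, but the gap to compound 1 lies within the scatter, so the two read-outs cannot be told apart.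

Compound 3 `COc1cc(Cl)cc(-c2nn(-c3cccc(NC(=O)Nc4cccc(C(F)(F)F)c4)c3)cc2-c2ccncc2)c1` is not yet measured. It differs from compound 2 in one place: 3-(trifluoromethyl)phenyl in place of 3,4-dichlorophenyl on an amide-type nitrogen. Among the measured compounds shown here, no measured pair shows this change, and the two measured compounds, which differ only in the group on that same amide-type nitrogen, sit within the scatter of each other.

The expected step from compound 2 to compound 3 in this assay is therefore a number 1 percentage points higher from compound 2 to compound 3 (within the scatter), none beyond the scatter. For compound 3 in this assay the estimate is 96%, with a range from 86% to 104%.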

Compound 3, a percentage reported as activity, at one concentration (the size of the read-out at that concentration, not a potency): 94%
The estimate for compound 3 lay 2 percentage points above the measured number; low and high end bracket the measured number.
By their numbers in this assay, from the lowest: compounds 3, 2 and 1 (each within the scatter of the next).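

In this assay, among the compounds shown here, 3-(trifluoromethyl)phenyl in place of 3,4-dichlorophenyl on the amide-type nitrogen gives a number 1 percentage points lower from compound 2 to compound 3 (within the scatter), the first direct reading of this change. Hydrogen in place of trifluoromethyl on an aromatic carbon of the aryl group gives a number 5 percentage points lower from compound 1 to compound 3 (within the scatter), so neither change at this position separates the compounds at the one concentration tested. Nothing at hand explains these readings.

Still open, as far as these compounds go, is whether a different group on the amide-type nitrogen, such as a pyridine ring, a cyclohexyl ring or an aryl ring carrying an amine or a carboxylic acid, would shift the read-out beyond the scatter. These single-concentration read-outs also give no potency for compound 1, compound 2 or compound 3.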